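The source may hold more compounds than are shown below. What is called first, only, known or untested is meant among the compounds shown, and "the series" means these compounds.

Compounds measured so far:
compound 1, `CNc1nc(-c2cc(OC)c(OC)c(OC)c2)c(-c2ccc(C)cc2)s1`, 18.1 nM;
compound 2, `CNc1nc(-c2cc(OC)c(OC)c(OC)c2)c(-c2ccc(C(F)(F)F)cc2)s1`, 3170 nM;
compound 3, `COc1cc(-c2nc(C)sc2-c2ccc(C)cc2)cc(OC)c1OC`, 1510 nM.

All three were tested in a functional assay on HL-60 cells (Homo sapiens) for antiproliferative activity, read by MTT assay, with a stated time of 72 h; on this read-out higher numbers stand for weaker inhibition and lower numbers for stronger inhibition. Compound 1 gives 18.1 nM in this assay, and two single changes to it are measured. The change trifluoromethyl in place of methyl on an aromatic carbon produces a 180-fold higher number from compound 1 to compound 2 (2.24 log units; beyond the scatter). The change methyl in place of methylamino on an aromatic carbon produces an 83-fold higher number from compound 1 to compound 3 (1.92 log units; beyond the scatter), so compound 3 stands far from compound 1, and its value and that of compound 2 are separated by a step that is beyond the scatter.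

Compound 4, `COc1cc(-c2nc(C)sc2-c2ccc(C(F)(F)F)cc2)cc(OC)c1OC`, is not yet measured. It differs from compound 3 by trifluoromethyl in place of methyl on an aromatic carbon, which is the same change as trifluoromethyl in place of methyl on an aromatic carbon, made at a place described in the same words. The two cores differ by methyl in place of methylamino on an aromatic carbon.

Beside a 180-fold higher number from compound 1 to compound 2 (2.24 log units; beyond the scatter), compound 4 is expected to show a 20-fold higher number from compound 3 to compound 4 (1.30 log units; beyond the scatter) in this assay. The expectation of a smaller step rests on compound 3 already giving 1510 nM, leaving less room for a further rise of the same size. For compound 4 the estimate is 30000 nM, expected to fall between 8000 nM and 150000 nM.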

Compound 4, half-maximal inhibitory concentration: > 10000 nM
Compound 4: no number, only a limit; the forecaster's own chance of this, stated with the estimate: 30%; the middle value does not contradict the limit.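

In this assay the entry for compound 4, > 10000 nM, is a limit of the assay and not a number. Carried to a second core, trifluoromethyl in place of methyl again gives a higher number, an at least 6.6-fold higher number from compound 3 to compound 4 (0.82 log units; beyond the scatter), so the direction of the change holds on both cores, but its size on the two cores cannot be compared: the same change on two cores in this assay, a 180-fold higher number (2.24 log units; beyond the scatter) from compound 1 to compound 2 and an at least 6.6-fold higher number (0.82 log units; beyond the scatter) from compound 3 to compound 4; the limit leaves it open whether they differ. Methyl in place of methylamino likewise gives a higher number on the trifluoromethyl-bearing core, an at least 3.1-fold higher number from compound 2 to compound 4 (0.49 log units; beyond the scatter), which again shows a shared direction and not a shared size: the same change on two cores in this assay, an 83-fold higher number (1.92 log units; beyond the scatter) from compound 1 to compound 3 and an at least 3.1-fold higher number (0.49 log units; beyond the scatter) from compound 2 to compound 4; the limit leaves it open whether they differ.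

Among the compounds shown here, these four compounds cover only two cores and two groups at each of the two places that vary, so they support no rule beyond this set. From the compounds shown here alone, it remains open how chlorine or ethyl at the place of the trifluoromethyl would behave, and whether a free amine or a longer alkylamino chain could stand in for methylamino.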